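Methoxyphenyl positional swap on the fused bicyclic core

A few compounds are considered here, and "the series" means these few. Any claim that something is new, unique, unknown or untested is made for them only; others in the source may bear on it.

Measured so far:
- compound 1, `C=C(Br)C(=O)Nc1cccc(-c2cn3nc(-c4ccc(CC)cc4)sc3n2)c1`: 3400 nM
- compound 2, `C=C(Br)C(=O)Nc1cccc(-c2cn3nc(-c4cccc(OC)c4)sc3n2)c1`: 1200 nM

In a functional assay on CCRF-CEM cells (Homo sapiens) for inhibition, read by cell counting, with a stated time of 3 days (on this read-out lower numbers stand for stronger inhibition and higher numbers for weaker inhibition), compound 2 gives the lowest of the two numbers; its nearest neighbour is compound 1, and the step of a 2.8-fold lower number from compound 1 to compound 2 (0.45 log units; beyond the scatter) lies beyond the scatter. That step exchanges two substituents at once, the group itself and where it sits on the phenyl ring, so it cannot be split into separate contributions.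

Compound 3, `C=C(Br)C(=O)Nc1cccc(-c2cn3nc(-c4ccc(OC)cc4)sc3n2)c1`, is not yet measured. It differs from compound 2 by 4-methoxyphenyl in place of 3-methoxyphenyl on an aromatic carbon. Among the compounds with values here, no measured step isolates this change. Within the data shown here, the only step that touches the same attachment point, a 2.8-fold lower number from compound 1 to compound 2 (0.45 log units; beyond the scatter), moved from 4-ethylphenyl to 3-methoxyphenyl and gave a modest gain, which leaves open whether the methoxy group or its position carried the effect. On that basis a small shift toward a higher number than compound 2 is expected, but within a broad range that includes no change beyond the scatter.

For compound 3 the estimate is 1800 nM (range 700 nM to 5000 nM), meaning an expected step of a 1.5-fold higher number from compound 2 to compound 3 (0.18 log units; within the scatter).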

Compound 3, half-maximal inhibitory concentration: 1200 nM
Compound 3: the middle estimate sits 1.5-fold (0.18 log units) above what was measured, and the stated range covers the measured number.
By their numbers in this assay, from the lowest: compounds 2 and 3 (each within the scatter of the next); then compound 1.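

In this assay, 4-methoxyphenyl in place of 3-methoxyphenyl on this aromatic carbon gives no change at the digits printed from compound 2 to compound 3 (within the scatter) and so does not separate the two methoxyphenyl groups. Keeping the substituent where it stands in 4-ethylphenyl, methoxy in place of ethyl gives a 2.8-fold lower number from compound 1 to compound 3 (0.45 log units; beyond the scatter) and so shows a change of group alone, beyond the scatter, which the earlier step from 4-ethylphenyl to 3-methoxyphenyl could not isolate. No supporting measurement bears on why methoxy and ethyl differ in this series.

The compounds shown leave open how a dimethylamino group, a carboxylic acid or a longer chain such as propoxy would read out on the same phenyl ring, relative to the methoxy pair, compound 2 and compound 3. They also leave open whether 3-ethylphenyl would match 4-ethylphenyl, so the lack of separation between the two placements is shown for methoxy only and cannot yet be extended to other groups at this attachment point.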